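Swapping a substituted benzyl for an oxane ring

The source may report more compounds than this note shows. Statements on the series, on what has been measured and on what is new or still open speak of the compounds shown alone.

Measured so far:
- compound 1, `CCNC(=O)c1cc(C(=O)NC)c(=O)n(Cc2ccccc2)c1`, in a physicochemical assay for lipophilicity, at pH 7.4 (a higher number here means a more lipophilic compound, a lower number a more polar compound), gives 3
- compound 2, `CNC(=O)c1ccc(=O)n(Cc2ccccc2)c1`, in this assay gives 1.6
- compound 3, `CNC(=O)c1cc(C(=O)NC2CC2)cn(Cc2cccc([C@@H](C)O)c2)c1=O`, in this assay gives 2.2

Among these three numbers compound 3 stands second highest. Its nearest neighbour is compound 2, which sits lower by a gap beyond the usual scatter, while compound 1 sits furthest away, higher by a gap that is also beyond the scatter.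

Compound 4, `CNC(=O)c1cc(C(=O)NC2CC2)cn(CC2CCOCC2)c1=O`, has not yet been measured. It differs from compound 3 in one place:

oxan-4-yl in place of 3-(1-hydroxyethyl)phenyl on a saturated chain carbon bound to an aromatic nitrogen

Within the data shown here, no pair of measured compounds differs in exactly this way, so there is no measured step to lean on. The group that leaves carries one hydrogen-bond donor, a six-membered aromatic ring of carbon only and three more heavy atoms than the group that enters; the oxan-4-yl that enters is a non-aromatic ring with one hetero atom and no donor. On balance a modest drop in this assay for compound 4 is expected, of a size that may only just exceed the scatter, so the step of a number 0.50 log units lower from compound 3 to compound 4 (beyond the scatter) is an estimate rather than a firm call. For compound 4 the expected value is 1.7, with a likely range from 1 to 2.4.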

Compound 4, distribution coefficient: 1.5
Compound 4: middle estimate off by 0.20 log units, on the high side, and the stated range covers the measured number.
By their numbers in this assay, from the lowest: compounds 4 and 2 (each within the scatter of the next); then compound 3; then compound 1.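

In this assay, among these compounds, putting oxan-4-yl in place of 3-(1-hydroxyethyl)phenyl on a saturated chain carbon bound to an aromatic nitrogen gives a number 0.70 log units lower from compound 3 to compound 4 (beyond the scatter), and this is the first comparison here in which only one place in the molecule changes. It shows that this place can move the reading beyond the scatter while the rest of the structure stays the same. The swap changes several things at once, since the entering group has fewer heavy atoms, no aromatic ring and no hydrogen-bond donor, and nothing measured here explains the step or divides it among those differences.

A cyclohexyl group in the same place would keep a saturated six-membered ring without its oxygen, and so would help to show how much of the step goes with that ring oxygen rather than with the loss of the aromatic ring and the hydroxyethyl group. The compounds shown also leave open how an amine or a carboxylic acid on this ring would read, and whether the same swap gives a step of similar size on a different core.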